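The source may hold more compounds than are shown below. What is called first, only, known or untested is meant among the compounds shown, and "the series" means these compounds.

Measured so far:
- compound 1 `C=C/C=C/[C@](C)(O)C/C=C/[C@H]1[C@H](O)CC(=O)[C@@H]1CC/C=C\CCC(=O)OC`: 0.243 mg/kg
- compound 2 `C=C(C)/C=C/[C@](C)(O)C/C=C/[C@H]1[C@H](O)CC(=O)[C@@H]1CC/C=C\CCC(=O)OC`: 0.42 mg/kg

In a functional assay on the whole organism with Rattus norvegicus as the target (on this read-out higher numbers stand for an effect only at larger amounts of compound and lower numbers for an effect already at smaller amounts), compound 2 gives 0.42 mg/kg, which lies within the scatter of compound 1. Compound 3 `C/C=C/C=C/[C@](C)(O)C/C=C/[C@H]1[C@H](O)CC(=O)[C@@H]1CC/C=C\CCC(=O)OC` differs from compound 2 by prop-1-en-1-yl in place of 1-methylethenyl on a double-bonded chain carbon bound to a double-bonded chain carbon: prop-1-en-1-yl in place of 1-methylethenyl. For the measured compounds named here, only one measured step bears on this change: a 1.7-fold higher number from compound 1 to compound 2 (0.24 log units; within the scatter), with methyl in place of hydrogen at the same place. No shift beyond the scatter is therefore expected in this assay. The expected result is a 1.2-fold lower number from compound 2 to compound 3 (0.08 log units; within the scatter). The estimate for compound 3 is 0.35 mg/kg, with an expected range of 0.15 mg/kg to 0.8 mg/kg.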

Compound 3, dose for half-maximal effect: 0.25 mg/kg
For compound 3 the middle estimate is 1.4-fold (0.15 log units) above the measured one; measured number inside the range.
By their numbers in this assay, from the lowest: compounds 1, 3 and 2 (each within the scatter of the next).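

Prop-1-en-1-yl in place of 1-methylethenyl (a 1.7-fold lower number from compound 2 to compound 3 (0.23 log units; within the scatter)) and prop-1-en-1-yl in place of vinyl (a 1.0-fold higher number from compound 1 to compound 3 (0.01 log units; within the scatter)) both stay flat in this assay. On a double-bonded chain carbon bound to a double-bonded chain carbon, the way these atoms are joined therefore does not separate compound 2 from compound 3, and neither of them separates from compound 1. No measurement available here accounts for this flatness. As far as these compounds go, whether a longer chain, an amine or a carboxylic acid at this place would move the number beyond the scatter remains open.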